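Substituted anilino variants on the shared core

This account rests on a few compounds, and the source may have more. Where it says the series, first, only, none or still open, it means among the compounds named here.

Measured compounds:
compound 1 `Cc1cc(=O)oc2cc(OCc3nc(N)nc(Nc4ccc(Cl)cc4)n3)ccc12` — 32500 nM
compound 2 `Cc1cc(=O)oc2cc(OCc3nc(N)nc(Nc4ccc(C(C)C)cc4)n3)ccc12` — 460 nM
compound 3 `Cc1cc(Nc2nc(N)nc(COc3ccc4c(C)cc(=O)oc4c3)n2)ccc1Cl` — 240 nM

In an assay on COS-7 cells for agonist activity at Free fatty acid receptor 1 (Homo sapiens), read by scintillation counting and inositol phosphate accumulation, with a stated time of 90 min (on this read-out lower numbers stand for an effect already at smaller amounts and higher numbers for an effect only at larger amounts of compound), compound 3 gives the lowest number of the three, though its step to compound 2 is within the scatter a 1.9-fold lower number from compound 2 to compound 3 (0.28 log units; within the scatter); only compound 1 stands clearly apart a 140-fold lower number from compound 1 to compound 3 (2.13 log units; beyond the scatter).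

The next compound, compound 4 `Cc1c(Cl)cc(Nc2nc(N)nc(COc3ccc4c(C)cc(=O)oc4c3)n2)cc1Cl`, carries 3,5-dichloro-4-methylphenyl in place of 4-chloro-3-methylphenyl on a nitrogen on an aromatic ring. Within the data shown here, no measured step tests this exact change. The nearest evidence is that substituents on this phenyl ring moved the numbers strongly: a 140-fold lower number from compound 1 to compound 3 (2.13 log units; beyond the scatter) and a 71-fold lower number from compound 1 to compound 2 (1.85 log units; beyond the scatter), both large and beyond the scatter, while the two substituted phenyls themselves sit close together a 1.9-fold lower number from compound 2 to compound 3 (0.28 log units; within the scatter). Compound 4 keeps a substituted ring, so a number in the range of compounds 2 and 3 is the expectation, but the added chlorine and the shifted pattern leave the direction open. Compound 4 is expected near 320 nM, with a wide range from 60 nM to 1800 nM, which amounts to an estimated step of a 1.3-fold higher number from compound 3 to compound 4 (0.12 log units; within the scatter) that need not exceed the scatter.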

Compound 4, half-maximal effective concentration: 600 nM
Beside the measured number, compound 4's estimate is 1.9-fold (0.27 log units) below it; the range from low to high includes it.
By their numbers in this assay, from the lowest: compounds 3, 2 and 4 (each within the scatter of the next, the first and the last beyond it); then compound 1.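

In this assay, among these compounds, 3,5-dichloro-4-methylphenyl in place of 4-chloro-3-methylphenyl on a nitrogen on an aromatic ring gives a 2.5-fold higher number from compound 3 to compound 4 (0.40 log units; beyond the scatter), the first step beyond the scatter that does not involve compound 1, though only a modest one. The step of a 54-fold lower number from compound 1 to compound 4 (1.73 log units; beyond the scatter) remains large, while a 1.3-fold higher number from compound 2 to compound 4 (0.12 log units; within the scatter) does not separate the two, so this phenyl with two chlorines and a methyl stays with the substituted rings of compounds 2 and 3, clear of the 4-chlorophenyl of compound 1. No measurement at hand accounts for these differences.

The change in compound 4 combines an added chlorine with a different placing of the methyl, and the compounds shown do not separate the two. Also open, from the compounds shown here alone, is how this phenyl would respond to a methoxy group, an amine or a carboxylic acid in place of chlorine.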